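Swapping a Sulfated Chain for Phenyl on a Sugar Scaffold

This account rests on a few compounds, and the source may have more. Where it says the series, first, only, none or still open, it means among the compounds named here.

Compound 2 `CCN(CC(=O)NC[C@H]1O[C@H](OC)[C@@H](OS(=O)(=O)O)[C@@H](OS(=O)(=O)O)[C@@H]1OS(=O)(=O)O)C(=O)CCCCCCCCCOS(=O)(=O)O` was tested in an assay on isolated protein for binding affinity to fibroblast growth factor 1 (Homo sapiens), read by surface plasmon resonance (a higher number here means weaker binding, a lower number tighter binding), and gives 111000 nM. Among the three measured compounds this is the second highest number: compound 1 `CCN(CC(=O)NC[C@H]1O[C@H](OC)[C@@H](OS(=O)(=O)O)[C@@H](OS(=O)(=O)O)[C@@H]1OS(=O)(=O)O)C(=O)COS(=O)(=O)O` gives 174000 nM, a difference from compound 2 within the usual scatter, while compound 3 `CCN(CC(=O)NCCO[C@H]1O[C@H](COS(=O)(=O)O)[C@@H](OS(=O)(=O)O)[C@H](OS(=O)(=O)O)[C@@H]1OS(=O)(=O)O)C(=O)CCCCCCCCCOS(=O)(=O)O` gives 20000 nM, a lower number beyond the scatter. Compound 4 `CCN(CC(=O)NC[C@H]1O[C@H](OC)[C@@H](OS(=O)(=O)O)[C@@H](OS(=O)(=O)O)[C@@H]1OS(=O)(=O)O)C(=O)CCCc1ccccc1` differs from compound 2 by one change: phenyl in place of 6-(sulfooxy)hexyl on a saturated chain carbon, three bonds along the chain from a carbonyl carbon. Going by the values given here, no measured pair shows this change, so the direction is uncertain. Since compound 2 gives 111000 nM while still carrying the 6-(sulfooxy)hexyl chain, the expected step is a 2.3-fold higher number from compound 2 to compound 4 (0.35 log units; beyond the scatter), toward a higher number. Compound 4 is therefore estimated at 250000 nM, in a range from 100000 nM to 600000 nM.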

Compound 4, dissociation constant: 500000 nM
Compound 4: the middle estimate sits 2.0-fold (0.30 log units) below what was measured; the measured number falls inside the stated range.
By their numbers in this assay, from the lowest: compound 3; then compounds 2 and 1 (each within the scatter of the next); then compound 4.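

Phenyl in place of 6-(sulfooxy)hexyl gives a 4.5-fold higher number from compound 2 to compound 4 (0.65 log units; beyond the scatter), and phenethyl in place of sulfooxy gives a 2.9-fold higher number from compound 1 to compound 4 (0.46 log units; beyond the scatter). Both steps point toward weaker binding, so the chain ending in sulfooxy, short or long, binds tighter here than the chain ending in phenyl. Nothing measured explains this difference.

Still open, as far as these compounds go, is whether the sulfooxy group itself matters or the chain carrying it. A plain alkyl chain of the same length, or a carboxylic acid at the chain end, would help separate the two.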